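Swapping a Short Chain for a Ring at the Sulfur

The source may report more compounds than this note shows. Statements on the series, on what has been measured and on what is new or still open speak of the compounds shown alone.

Compound 1 `C#CCSc1nc(N/N=C(\C)c2ccccc2O)c2nnn(Cc3ccccc3)c2n1`: 11300 nM
Compound 2 `CCCSc1nc(N/N=C(\C)c2ccccc2O)c2nnn(Cc3ccccc3)c2n1`: 11000 nM

In a functional assay on MCF7 cells (Homo sapiens) for antiproliferative activity, read by MTT assay, with a stated time of 72 h (a higher number here means a weaker inhibitor, a lower number a stronger inhibitor), compound 2 stands within the scatter of compound 1, since the step of a 1.0-fold lower number from compound 1 to compound 2 (0.01 log units; within the scatter) is too small to separate them. Compound 3 `C/C(=N\Nc1nc(SCc2ccccc2)nc2c1nnn2Cc1ccccc1)c1ccccc1O` alters the same position again: phenyl in place of ethyl on a saturated chain carbon bound to a sulfur. For the measured compounds named here, the only measured step at this place, a 1.0-fold lower number from compound 1 to compound 2 (0.01 log units; within the scatter), lay within the scatter, and no measured pair swaps a chain for a ring, so the data point in no direction. For compound 3 the expected step is a 1.1-fold lower number from compound 2 to compound 3 (0.04 log units; within the scatter). Compound 3 is therefore estimated at 10000 nM, ranging from 3500 nM to 28000 nM.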

Compound 3, half-maximal inhibitory concentration: 950 nM
For compound 3 the middle estimate is 11-fold (1.02 log units) above the measured one; the measured number lies below the stated range.
By their numbers in this assay, from the lowest: compound 3; then compounds 2 and 1 (each within the scatter of the next).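

The two short chains could not be told apart, but a ring at this place moves the number well beyond the scatter: in this assay, phenyl in place of ethyl gives a 12-fold lower number from compound 2 to compound 3 (1.06 log units; beyond the scatter), and phenyl in place of ethynyl gives a 12-fold lower number from compound 1 to compound 3 (1.08 log units; beyond the scatter). Compound 3 therefore stands lowest of the three. No measured evidence here explains this gain.

Going by these compounds, whether a ring is required, or a longer chain such as pentyl would serve as well, remains open. So does the effect of adding an amine to the phenyl ring.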